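The compounds below may be only part of what the source reports. "The series", "measured", "known", "first", "only" and "open" are said of these compounds alone.

Measured so far:
- compound 1, `CCOc1ccc(-c2ccc3ncn(-c4cc(OC)c(OC)c(OC)c4)c3c2)cc1`: 8550 nM
- compound 2, `COc1cc(-n2cnc3ccc(-c4cccc(O)c4)cc32)cc(OC)c1OC`: 250 nM

In a functional assay on A549 cells (Homo sapiens) for antiproliferative activity, read by MTT assay, with a stated time of 72 h (on this read-out higher numbers stand for weaker inhibition and lower numbers for stronger inhibition), compound 2 stands lowest of the two numbers measured; its nearest neighbour is compound 1, and the step of a 34-fold lower number from compound 1 to compound 2 (1.53 log units; beyond the scatter) separates them. That step exchanges the whole aryl group, 3-hydroxyphenyl in place of 4-ethoxyphenyl, so it changes both the substituent and where it sits at once.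

Compound 3, `COc1cccc(-c2ccc3ncn(-c4cc(OC)c(OC)c(OC)c4)c3c2)c1`, has yet to be measured in this assay. It differs from compound 2 by methyl in place of hydrogen on an oxygen on an aromatic ring; cut one bond further out, the change reads hydroxy to methoxy, 3-hydroxyphenyl to 3-methoxyphenyl.

Among the measured compounds shown here, only one measured step is available, and it bears on this change loosely: it shows that the pairing of an unsubstituted oxygen with compound 2 goes together with the lower number, whereas the alkylated oxygen of compound 1 sits with the higher one. For the measured compounds named here, no measured pair isolates the oxygen substituent alone. A modest rise in the number for compound 3 is therefore expected, a 2.4-fold higher number from compound 2 to compound 3 (0.38 log units; beyond the scatter), without confidence that it exceeds the scatter.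

Compound 3 is estimated at 600 nM, within 200 nM to 2500 nM.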

Compound 3, half-maximal inhibitory concentration: 3180 nM
Compound 3: the middle estimate sits 5.3-fold (0.72 log units) below what was measured; the whole stated range lies below it.
By their numbers in this assay, from the lowest: compound 2; then compound 3; then compound 1.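

In this assay, among the compounds shown here, the step from hydroxy to methoxy on 3-hydroxyphenyl isolates the oxygen substituent for the first time, with the rest of the structure unchanged: a 13-fold higher number from compound 2 to compound 3 (1.10 log units; beyond the scatter). This single added methyl thus accounts for the larger part of the gap seen earlier, and the free hydroxy goes with the lowest number among the three compounds. What remains, a 2.7-fold lower number from compound 1 to compound 3 (0.43 log units; beyond the scatter), still combines a change from methoxy to ethoxy with a change from 3-substituted to 4-substituted phenyl, so the two contributions cannot be separated; no supporting data bear on why the methyl has so large an effect.

The compounds shown leave open whether the low number of compound 2 depends on the hydroxy itself, since an amine or a carboxylic acid in its place would test how specific the requirement is. They also leave open how the number responds to a longer chain on that oxygen, as a 3-ethoxyphenyl group would show, and such a compound would also separate the effect of the chain from that of its place on the phenyl ring.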